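The source may hold more compounds than are shown below. What is called first, only, known or untested is meant among the compounds shown, and "the series" means these compounds.

In a functional assay on MDA-MB-435 cells (Homo sapiens) for cytotoxicity, read by MTT assay, with a stated time of 72 h (on this read-out higher numbers stand for weaker inhibition and lower numbers for stronger inhibition), compound 1 `N[C@H]1CC[C@H](Nc2c(C(=O)NCc3ccc(Cl)cc3Cl)nc(Br)c3cccnc23)CC1` gives 5800 nM. Compound 2 `O=C(NCc1ccc(F)cc1)c1nc(Br)c2cccnc2c1N1CCNCC1` gives 8000 nM, and these two numbers lie within the usual scatter of each other, so neither can be ranked over the other. Compound 3 `C[C@H](CO)Nc1nc(C(=O)NCc2ccc(F)cc2)c(O)c2ncccc12` reads > 20000 nM, which is a limit of the assay and not a number. Among the measured compounds shown here, compound 1 therefore stands level with compound 2, and these are the only two true numbers available.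

Compound 4 `N[C@H]1CC[C@H](Nc2c(C(=O)NCc3cccs3)nc(Br)c3cccnc23)CC1` differs from compound 1 in one place: thiophen-2-yl stands in place of 2,4-dichlorophenyl on a saturated chain carbon bound to an amide-type nitrogen (thiophen-2-yl in place of 2,4-dichlorophenyl on a saturated chain carbon bound to an amide-type nitrogen). For the measured compounds named here, no two measured compounds differ in just one place, so the data offer no direct guide to this swap. In this assay the expected step of a 1.4-fold higher number from compound 1 to compound 4 (0.14 log units; within the scatter) is small, leaning toward weaker inhibition and hardly beyond the scatter. For compound 4 the estimate is 8000 nM, with an expected range of 3000 nM to 20000 nM.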

Compound 4, half-maximal inhibitory concentration: 4100 nM
The estimate for compound 4 lay 2.0-fold (0.29 log units) above the measured number; the measured number falls inside the stated range.
By their numbers in this assay, from the lowest: compounds 4, 1 and 2 (each within the scatter of the next). At a limit, above all of these: compound 3.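

In this assay, putting thiophen-2-yl in place of 2,4-dichlorophenyl on a saturated chain carbon bound to an amide-type nitrogen gives a 1.4-fold lower number from compound 1 to compound 4 (0.15 log units; within the scatter), so the two compounds cannot be ranked. Among the compounds shown here, this is the only direct reading at this place, and it shows that a six-membered aromatic ring of carbon carrying two chlorine atoms and a five-membered aromatic ring holding one sulfur atom read alike here, on the shared core. Nothing given here bears on why the two read alike.

The compounds shown offer just this one swap at this place, so it stays open whether other groups would also read alike. A pyridin-2-yl ring, or a chain ending in an amine or a carboxylic acid, could show whether this place tolerates larger changes.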